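A few compounds are considered here, and "the series" means these few. Any claim that something is new, unique, unknown or untested is made for them only; others in the source may bear on it.

Compound 1 `CCC1=C(C(=O)OCC2CCCCC2)C(c2cccc(O)c2)NC(=O)N1`: > 10000 nM (a limit)
Compound 2 `COc1ccc(-c2nc(CC(=O)c3cccc(Cl)c3)nc3ccsc23)cn1`: 30000 nM

For the measured compounds named here, in an ADME assay on cells (Homo sapiens) for cytotoxicity, read by resazurin assay, with a stated time of 5 days (a higher number here means that more compound is tolerated, a lower number that less compound is tolerated), compound 2 gives 30000 nM, the only true number in this small set. The reading for compound 1 is a limit of the assay and not a number. The two compounds therefore cannot be ranked against each other.

Next in line is compound 3 `COc1ccc(-c2nc(COc3cccc(Cl)c3)nc3ccsc23)cn1`, which keeps the rest of compound 2 and carries 3-chlorophenoxy in place of (3-chlorophenyl)carbonyl on a saturated chain carbon bound to an aromatic carbon. Going by the values given here, no measured pair in this assay shows what this exchange does, so the only anchor is compound 2 at 30000 nM, and no change beyond the usual scatter is expected in either direction. The expected step is a 1.2-fold lower number from compound 2 to compound 3 (0.08 log units; within the scatter). A reading reported only as a limit would also not be a surprise. Compound 3 is estimated at 25000 nM, with an expected range of 8000 nM to 70000 nM.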

Compound 3, half-maximal cytotoxic concentration: > 50000 nM
Compound 3: no number, only a limit (the forecaster's own chance of this, stated with the estimate: 35%); middle value at least 2.0-fold (0.30 log units) from the limit.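

Placing 3-chlorophenoxy in place of (3-chlorophenyl)carbonyl on a saturated chain carbon bound to an aromatic carbon gives an at least 1.6-fold higher number from compound 2 to compound 3 (0.22 log units; that floor lies within the scatter) in this assay, the first step read in this series and the first view of this position. As far as these compounds go, the reading for compound 3 is a limit and not a number, and the size of the step stays open because of that limit: the limit of > 50000 nM in this assay, at which 1 of the 3 values shown sits. What can be said is that this exchange, with one heavy atom fewer in the entering group and the same count of hydrogen-bond acceptors, brings no drop in the number, while the floor of the step does not by itself establish a real rise.

The compounds shown leave open how far the tolerated concentration of compound 3 actually lies from that of compound 2, and whether the chlorine of the 3-chlorophenoxy group plays any part in the reading. They also leave open what an amine, a carboxylic acid or a longer chain on the same saturated chain carbon would do in this assay.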